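From butyl to cyclohexyl: a step still unmeasured

The source may report more compounds than this note shows. Statements on the series, on what has been measured and on what is new or still open speak of the compounds shown alone.

Compound 1 `O=C(NCc1cc(Cl)ccc1-n1cnnn1)[C@@H]1CC=NN1C(=O)[C@H](O)c1ccccc1`: 840 nM
Compound 2 `CCCC[C@@H](O)C(=O)N1N=CC[C@H]1C(=O)NCc1cc(Cl)ccc1-n1cnnn1`: 610 nM

In a functional assay on a cell-free system (plasma, Homo sapiens), with a stated time of 3 min (on this read-out lower numbers stand for stronger inhibition and higher numbers for weaker inhibition), compound 2 gives 610 nM and compound 1 gives 840 nM, so the two values lie within the usual scatter of each other and neither stands apart. The open step leads to compound 3 `O=C(NCc1cc(Cl)ccc1-n1cnnn1)[C@@H]1CC=NN1C(=O)[C@H](O)C1CCCCC1`, which carries cyclohexyl in place of butyl on a saturated chain carbon bound to a carbonyl carbon and an oxygen on a saturated carbon. Within the data shown here, only one measured step bears on this change, since it falls at the same place, where butyl stands in place of phenyl: a 1.4-fold lower number from compound 1 to compound 2 (0.14 log units; within the scatter). Among the measured compounds shown here, no compound with cyclohexyl has yet been measured, so that single small step is the only guide. No step beyond the scatter is therefore expected in this assay, and neither direction is favoured. The estimate amounts to an expected 1.1-fold higher number from compound 2 to compound 3 (0.03 log units; within the scatter) and so stays within that range of noise. For compound 3 the expected value is 650 nM, with an estimated range from 280 nM to 1500 nM.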

Compound 3, half-maximal inhibitory concentration: 970 nM
Estimate against measurement, compound 3: 1.5-fold (0.17 log units) below; the range from low to high includes it.
By their numbers in this assay, from the lowest: compounds 2, 1 and 3 (each within the scatter of the next).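

At this position, on a saturated chain carbon bound to a carbonyl carbon and an oxygen on a saturated carbon, this assay now covers an open chain, an aromatic ring and a non-aromatic ring, and the new compound gives a 1.6-fold higher number from compound 2 to compound 3 (0.20 log units; within the scatter) and a 1.2-fold higher number from compound 1 to compound 3 (0.06 log units; within the scatter). Butyl, phenyl and cyclohexyl therefore cannot be told apart here: exchanging either earlier group for a six-membered non-aromatic ring of carbon only leaves the number within the scatter, so this position has so far tolerated all three groups in this read-out. Nothing in the data shown gives a reason for these values.

As far as these compounds go, all three groups are hydrocarbons, so it remains open whether an amine or a carboxylic acid at this same carbon would move the number beyond the scatter. Also open is whether a methyl group or a chain longer than butyl would do so, since the compounds shown cover neither a smaller group nor a longer one.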